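The compounds below may be only part of what the source reports. "The series", "measured", "known", "first", "only" and "open" are said of these compounds alone.

In a functional assay on HCT-116 cells (Homo sapiens) for cytotoxicity, read by MTT assay, with a stated time of 72 h (a higher number here means a weaker inhibitor, a lower number a stronger inhibitor), compound 1 (`O=C1c2c[n+]([O-])c3ccccc3c2C(=O)c2c1c1ccccc1n2CCN1CCCC1`) gives 270 nM, while compound 2 (`CCCN1CCN(CCCCn2c3c(c4ccccc42)C(=O)c2c[n+]([O-])c4ccccc4c2C3=O)CC1`) gives 790 nM, the higher of the two numbers. Compound 3 (`CN(C)CCCCn1c2c(c3ccccc31)C(=O)c1c[n+]([O-])c3ccccc3c1C2=O`) remains unmeasured and differs from compound 2 by dimethylamino in place of 4-propylpiperazin-1-yl on a saturated chain carbon, four bonds along the chain from an aromatic nitrogen. Within the data shown here, the only measured step, a 2.9-fold higher number from compound 1 to compound 2 (0.47 log units; beyond the scatter), is modest but beyond the scatter, and it put 2-(4-propylpiperazin-1-yl)ethyl in place of pyrrolidin-1-yl. Removing 4-propylpiperazin-1-yl is therefore expected to give a modest move towards a lower number in this assay. The expected step is a 1.9-fold lower number from compound 2 to compound 3 (0.27 log units; within the scatter). For compound 3 the estimated value is 420 nM, with an expected range of 150 nM to 1200 nM.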

Compound 3, half-maximal inhibitory concentration: 450 nM
The estimate for compound 3 lay 1.1-fold (0.03 log units) below the measured number, within the range that was stated.
By their numbers in this assay, from the lowest: compounds 1, 3 and 2 (each within the scatter of the next, the first and the last beyond it).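

In this assay, dimethylamino in place of 4-propylpiperazin-1-yl gives a 1.8-fold lower number from compound 2 to compound 3 (0.24 log units; within the scatter), so at this chain position the piperazine ring can be lost without a step beyond the scatter. 2-(dimethylamino)ethyl in place of pyrrolidin-1-yl also stays inside the scatter, at a 1.7-fold higher number from compound 1 to compound 3 (0.22 log units; within the scatter), which leaves the earlier pair as the only one separated beyond it. No measured evidence bears on these results. Still open, as far as these compounds go, is how a morpholine, a primary amine or a longer chain would read in this assay.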